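Dropping the Sulfamoyl Group: From Compound 1 to Compound 4

A few compounds are considered here, and "the series" means these few. Any claim that something is new, unique, unknown or untested is made for them only; others in the source may bear on it.

In a functional assay on A549 cells (Homo sapiens) for inhibition (on this read-out higher numbers stand for weaker inhibition and lower numbers for stronger inhibition), compound 1 `N#CC1CN1C(=O)Nc1ccc(S(N)(=O)=O)cc1` gives > 38000 nM, which is a limit of the assay rather than a number (the limit of > 38000 nM in this assay, at which 1 of the 3 values shown sits). Compound 2 `CCCCNC(=O)N1CC1C#N` gives 18000 nM in this assay, and compound 3 `CC(C)(C)NC(=O)N1CC1C#N` gives 180000 nM. For the measured compounds named here, the only measured step, a 10-fold higher number from compound 2 to compound 3 (1.00 log units; beyond the scatter), concerns the group on the amide-type nitrogen. Compound 4 `N#CC1CN1C(=O)Nc1ccccc1` differs from compound 1 at another place: hydrogen in place of sulfamoyl on an aromatic carbon. Going by the values given here, no measured step touches this position, so nothing shows whether removing the sulfamoyl should raise or lower the number, and no step beyond the scatter is expected in either direction. The estimate for compound 4 is therefore 40000 nM, with a range from 8000 nM to 200000 nM, which means an expected step that the limit leaves unreadable from compound 1 to compound 4.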

Compound 4, half-maximal inhibitory concentration: 9000 nM
Compound 4: middle estimate off by 4.4-fold (0.65 log units), on the high side; the range from low to high includes it.
By their numbers in this assay, from the lowest: compounds 4 and 2 (each within the scatter of the next); then compound 3.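

For the compounds shown here, with hydrogen in place of sulfamoyl on the aromatic carbon, this assay shows an at least 4.2-fold lower number from compound 1 to compound 4 (0.62 log units; beyond the scatter), so this position, which no earlier step touched, does matter, and inhibition is stronger without the sulfamoyl. Compound 1 gives > 38000 nM, which is a limit of the assay and not a number. The full size of the step therefore stays unknown: the limit of > 38000 nM in this assay, at which 1 of the 4 values shown sits.

Only sulfamoyl and hydrogen are shown at this carbon. From the compounds shown here alone, it stays open whether an amine or a carboxylic acid there would behave more like sulfamoyl or like hydrogen.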